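This account rests on a few compounds, and the source may have more. Where it says the series, first, only, none or still open, it means among the compounds named here.

Measured compounds:
compound 1, `COc1ccc(Br)cc1C(=O)Nc1ccc(Sc2nc3ccccc3s2)cc1`: in an assay on isolated protein for inhibition of thiosulfate sulfurtransferase (Homo sapiens), with a stated time of 60 min, in the absence of a further agent (a higher number here means a weaker inhibitor, a lower number a stronger inhibitor), compound 1 gives > 100000 nM, a limit of the assay and not a number.
compound 2, `O=C(Nc1ccc(Sc2nc3ccccc3s2)cc1)c1cccc(Br)c1O`: in this assay compound 2 gives > 100000 nM, likewise a limit of the assay.

Among the compounds with values here, compound 2 therefore stands nowhere on a scale of numbers in this assay; it stands at the limit, as does the only other measured compound. Within the data shown here, the single measured step, a step that the two limits leave unreadable from compound 1 to compound 2, cannot be read, because both of its ends sit at the limit of > 100000 nM in this assay, at which 2 of the 2 values shown sit.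

Compound 3, `O=C(Nc1ccc(Sc2nc3ccccc3s2)cc1)c1cccc(Br)c1`, differs from compound 2 by hydrogen in place of hydroxy on an aromatic carbon. Among the measured compounds shown here, no measured step bears on this change: the step from compound 1 to compound 2 concerns a different part of the molecule and is in any case unreadable. The account thus has no direction and no size to carry over from the measured compounds, and what is known of compound 2 is only its limit.

On that basis compound 3 is expected to give about 150000 nM in this assay, with a range from 30000 nM to 1000000 nM. The step this estimate implies, expected at a step that the limit leaves unreadable from compound 2 to compound 3, is most likely to end again at the limit rather than at a readable number.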

Compound 3, half-maximal inhibitory concentration: > 100000 nM
Compound 3 gave a limit, no number; the forecaster's own chance of this, stated with the estimate: 85%; the middle value lies beyond the limit too.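

No new step can be read from compound 3: its steps from compound 1 and from compound 2 are both unreadable, because all three compounds give a limit of the assay and not a number: the limit of > 100000 nM in this assay, at which 3 of the 3 values shown sit. The compounds shown leave open how hydrogen, hydroxy and methoxy rank against one another in this assay, and whether any compound sharing this core gives a readable value there.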